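A few compounds are considered here, and "the series" means these few. Any claim that something is new, unique, unknown or untested is made for them only; others in the source may bear on it.

Measured compounds in the series:

compound 1, `COc1ccc(-c2cc(/C=C/C(=O)c3ccc(N)cc3)[nH]n2)cc1`: 6450 nM
compound 2, `COc1cc(-c2cc(/C=C/C(=O)c3ccc(Cl)c(Cl)c3)[nH]n2)cc(OC)c1OC`: > 100000 nM

In a functional assay on IGROV-1 cells (Homo sapiens) for inhibition, read by sulforhodamine B assay, with a stated time of 48 h (a lower number here means a stronger inhibitor of growth, a higher number a weaker inhibitor of growth), compound 1 gives a number, 6450 nM. For compound 2 the result in this assay is a limit of the assay and not a number, > 100000 nM. Compound 2 therefore sits at the limit of > 100000 nM in this assay, at which 1 of the 2 values shown sits, and the two compounds differ in more than one place, so no single step can be read between them.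

The next compound, compound 3, `COc1ccc(C(=O)/C=C/c2cc(-c3cc(OC)c(OC)c(OC)c3)n[nH]2)cc1`, is to be measured in this assay. It differs from compound 2 in one place: 4-methoxyphenyl in place of 3,4-dichlorophenyl on a carbonyl carbon. Within the data shown here, since no step between measured compounds is available, the expectation for this change rests on the shape of the two values shown. Compound 3 is expected to come out below the limit at which compound 2 sits, with a step of an at least 1.6-fold lower number from compound 2 to compound 3 (0.22 log units; that floor lies within the scatter) in this assay, though the chance that it too returns only a limit remains considerable. The estimate for compound 3 in this assay is 60000 nM, with a range from 10000 nM to 200000 nM.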

Compound 3, concentration for total growth inhibition: 4810 nM
Estimate against measurement, compound 3: 12-fold (1.10 log units) above, and the stated range ends above it.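

In this assay, among these compounds, 4-methoxyphenyl in place of 3,4-dichlorophenyl on a carbonyl carbon gives an at least 20-fold lower number from compound 2 to compound 3 (1.31 log units; beyond the scatter), the first step that can be read, and it shows that the group at this place is not indifferent for growth inhibition, even though the two groups count the same 8 heavy atoms and the entering one adds 1 hydrogen-bond acceptor. For compound 2 the value > 100000 nM is a limit of the assay and not a number. The step therefore gives only a floor, and its full size stays unknown because compound 2 sits at that limit: the limit of > 100000 nM in this assay, at which 1 of the 3 values shown sits.

As far as these compounds go, it remains open whether the difference follows from the methoxy group itself or from the loss of the two chlorines, a question that a plain phenyl group or a hydroxyl in place of the methoxy at the same place would bear on. Among the compounds shown here, compound 1 differs from both other compounds in more than one place, so no step to it can be read.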